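A few compounds are considered here, and "the series" means these few. Any claim that something is new, unique, unknown or untested is made for them only; others in the source may bear on it.

Measured compounds in a functional assay on U-251 cells (Homo sapiens) for cytotoxicity, read by sulforhodamine B assay, with a stated time of 48 h, tested at 0.001 uM; a higher number here means a weaker effect of the compound at the concentration tested, a lower number a stronger effect:
compound 1, `COc1cc(C)cc(-c2c(-c3ccnc(-c4ccc(C(C)=O)cc4)c3)cnn2CC#N)c1`, gives 104%
compound 2, `COc1cc(C)cc(-c2nn(CC#N)cc2-c2ccnc(-c3ccc(N(C)C)cc3)c2)c1`, gives 94%
compound 3, `Cc1cc(O)cc(-c2nn(CC#N)cc2-c2ccnc(-c3ccc(N(C)C)cc3)c2)c1`, gives 101%

Compound 1 stands within the scatter of both compound 3 and compound 2, so the three numbers cannot be told apart. Compound 4, `COc1cc(C)cc(-c2c(-c3ccnc(-c4ccc(N(C)C)cc4)c3)cnn2CC#N)c1`, differs from compound 1 by dimethylamino in place of acetyl on an aromatic carbon. Among the compounds with values here, the only measured step, a number 7 percentage points higher from compound 2 to compound 3 (within the scatter), concerns a different change and lies within the scatter; no measured step covers the exchange of acetyl for dimethylamino itself. Compound 2 and compound 3 both carry the dimethylamino group and sit where compound 1 sits, so no step beyond the scatter is expected in this assay. For compound 4 the expected step is a number 5 percentage points lower from compound 1 to compound 4 (within the scatter). Compound 4 is therefore estimated at 99%, with a range from 88% to 108%.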

Compound 4, a percentage reported as activity, at one concentration (the size of the read-out at that concentration, not a potency): 95%
Compound 4: the middle estimate sits 4 percentage points above what was measured, and the stated range covers the measured number.
By their numbers in this assay, from the lowest: compounds 2, 4, 3 and 1 (each within the scatter of the next).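

In this assay, dimethylamino in place of acetyl on the aromatic carbon para to a large group gives a number 9 percentage points lower from compound 1 to compound 4 (within the scatter). Within the data shown here, this is the first step read at this position, and at the single concentration tested the two groups cannot be told apart. Nothing available explains the result or bears on it.

On these data alone, whether a carboxylic acid or a primary amine on this aromatic carbon would give a step beyond the scatter remains open. Also open, as far as these compounds go, is whether acetyl and dimethylamino separate at higher concentrations.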